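Methyl for methoxy at the cytotoxicity limit

The compounds below may be only part of what the source reports. "The series", "measured", "known", "first", "only" and "open" are said of these compounds alone.

Compound 1 (`O=C(O)c1ccc(CCOc2c(F)ccc3nc(C(=O)NCC4CCCCC4)[nH]c(=O)c23)cc1`) gives > 20000 nM in an ADME assay on HEK293 cells (Homo sapiens) for cytotoxicity, read by resazurin assay, with a stated time of 72 h (on this read-out higher numbers stand for lower toxicity in this test and lower numbers for higher toxicity in this test), which is a limit and not a number. Compound 2 (`COc1cc(CNC(=O)c2nc3ccc(F)c(OCCc4ccc(C(=O)O)cc4)c3c(=O)[nH]2)ccc1F`) gives > 20000 nM, again a limit and not a number, so it stands without a measured number of its own. Going by the values given here, the only measured step, a step that the two limits leave unreadable from compound 1 to compound 2, puts 4-fluoro-3-methoxyphenyl in place of cyclohexyl. Compound 3 (`Cc1cc(CNC(=O)c2nc3ccc(F)c(OCCc4ccc(C(=O)O)cc4)c3c(=O)[nH]2)ccc1F`) carries methyl in place of methoxy on an aromatic carbon, ortho to a fluoro group: methyl in place of methoxy on an aromatic carbon. The measured step has no size to lend to this change because of the limit of > 20000 nM in this assay, at which 2 of the 2 values shown sit. No step beyond the usual scatter is therefore expected in this assay, and another limit is the likely report. The expected step is a step that the limit leaves unreadable from compound 2 to compound 3. For compound 3 the estimated value is 25000 nM, with an expected range from 12000 nM to 60000 nM.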

Compound 3, half-maximal cytotoxic concentration: > 20000 nM
Compound 3 was reported as a limit (the forecaster's own chance of this, stated with the estimate: 85%); the middle value lies beyond the limit too.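

No step between compound 1, compound 2 and compound 3 can be read, because all three stop at the same limit: the limit of > 20000 nM in this assay, at which 3 of the 3 values shown sit.

The compounds shown leave open where each true value lies in this assay, and so whether methyl in place of methoxy, or either phenyl group in place of cyclohexyl, changes this read-out at all.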